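A few compounds are considered here, and "the series" means these few. Any claim that something is new, unique, unknown or untested is made for them only; others in the source may bear on it.

Compound 1 `CCCCCCCCCCCC(=O)Nc1nnc(S[C@@H]2O[C@H](COC(C)=O)[C@H](OC(C)=O)[C@H](OC(C)=O)[C@H]2OC(C)=O)s1` gives 27700 nM in an ADME assay on CHO-K1 cells (Cricetulus griseus) for cytotoxicity, read by MTT assay, with a stated time of 24 h; a higher number here means a weaker inhibitor, a lower number a stronger inhibitor. Compound 2 `C=CCCCCCCCCC(=O)Nc1nnc(S[C@@H]2O[C@H](COC(C)=O)[C@H](OC(C)=O)[C@H](OC(C)=O)[C@H]2OC(C)=O)s1` gives 16300 nM in this assay. Compound 3 `CCCCCCCCCCCC(=O)Nc1nnc(S[C@@H]2O[C@H](CO)[C@H](O)[C@H](O)[C@H]2O)s1` is reported in this assay as "not active" (no number reported), with no number.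

Compound 1 and compound 2 share a core and differ in one place, (vinyl in place of propyl on a saturated chain carbon, eight bonds along the chain from a carbonyl carbon); the step of a 1.7-fold lower number from compound 1 to compound 2 (0.23 log units; within the scatter) is within the scatter. Compound 3 carries a different core, and the difference between the two cores is not broken down here. Compound 4 `C=CCCCCCCCCC(=O)Nc1nnc(S[C@@H]2O[C@H](CO)[C@H](O)[C@H](O)[C@H]2O)s1` stands to compound 3 as compound 2 stands to compound 1, by the same change, (vinyl in place of propyl on a saturated chain carbon, eight bonds along the chain from a carbonyl carbon).

For the measured compounds named here, compound 3 gave no number in this assay, so there is no measured step to set beside the earlier one. Since the same change in a 1.7-fold lower number from compound 1 to compound 2 (0.23 log units; within the scatter) stayed within the scatter, compound 4 is expected to look like compound 3 and to report little or no measurable inhibition, with an estimated value near 60000 nM, between 25000 nM and 200000 nM.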

Compound 4, half-maximal inhibitory concentration: "not active" (no number reported)
Compound 4 has no reported number here; the estimate stays without a comparison.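

Compound 3 and compound 4 are both reported as not active, without a number, in this assay, so no step can be read between them. As far as these compounds go, what vinyl in place of propyl does on this core stays open, and no supporting evidence bears on this result.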